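The source may hold more compounds than are shown below. What is called first, only, known or untested is meant among the compounds shown, and "the series" means these compounds.

In an ADME assay on the whole organism with Oryza sativa as the target, tested at 10 uM (on this read-out lower numbers stand for a stronger effect and higher numbers for a weaker effect at the one concentration tested), three compounds have been measured so far:
compound 1 `C[C@H](NC(=O)Nc1ccccc1Cl)c1ccccc1` gives 106%;
compound 2 `C[C@@H](NC(=O)Nc1cccc(Cl)c1)c1ccccc1` gives 83%;
compound 3 `C[C@H](NC(=O)Nc1ccc(Cl)cc1Cl)c1ccccc1` gives 99%.

Compound 1 and compound 2 are built from the same atoms joined differently; how their two cores differ is not broken down here. Compound 3 arises from compound 1 by chloro in place of hydrogen on an aromatic carbon, and that step gave a number 7 percentage points lower from compound 1 to compound 3 (within the scatter). Compound 4 `C[C@@H](NC(=O)Nc1ccc(Cl)c(Cl)c1)c1ccccc1`, not yet measured, arises from compound 2 by chloro in place of hydrogen on an aromatic carbon. In compound 3 the entering chloro sits meta to a chloro group, in compound 4 ortho to a chloro group, so this is the same kind of change, not the same one. Because the earlier step of a number 7 percentage points lower from compound 1 to compound 3 (within the scatter) stayed within the scatter, a similarly small step is expected here, a number 3 percentage points lower from compound 2 to compound 4 (within the scatter). Compound 4 is therefore estimated at 80%, expected to fall between 65% and 95%.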

Compound 4, a percentage reported as activity, at one concentration (the size of the read-out at that concentration, not a potency): 93%
Compound 4: middle estimate off by 13 percentage points, on the low side; low and high end bracket the measured number.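

In this assay, adding the chloro gave a number 10 percentage points higher from compound 2 to compound 4 (within the scatter), so on this core, as on the earlier one, the step alone stays within the usual scatter. Set side by side, however, the two steps do not agree: the same change on two cores in this assay, a number 7 percentage points lower (within the scatter) from compound 1 to compound 3 and a number 10 percentage points higher (within the scatter) from compound 2 to compound 4, 17 percentage points apart, beyond the scatter of two such steps

The size of this change on one core therefore cannot simply be carried over to the other core in this series. The two pairs show that the steps differ, but they do not show why, and two pairs are too few to give a rule.

All the substituents varied here are chloro groups. Going by these compounds, whether a methoxy group, a nitrile or an amine in their place would shift the number in this assay remains open.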